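A few compounds are considered here, and "the series" means these few. Any claim that something is new, unique, unknown or untested is made for them only; others in the source may bear on it.

Compound 2 `O=C1c2ccccc2N(Cc2ccccc2)S(=O)(=O)N1Cc1ccccc1` is the reference point here. Within the data shown here, in a functional assay on CCRF-CEM cells (Homo sapiens) for inhibition (a lower number here means that less compound is tolerated, a higher number that more compound is tolerated), compound 2 gives 108000 nM, the highest of the three numbers measured so far. Compound 3 `O=C1c2ccccc2N(Cc2ccccc2)S(=O)(=O)N1COCc1ccccc1` lies right next to it: in this assay compound 3 gives 100000 nM, and the step of a 1.1-fold lower number from compound 2 to compound 3 (0.03 log units; within the scatter) is within the scatter, so the two cannot be separated. Compound 1 `O=C1c2ccccc2N(COCc2ccccc2)S(=O)(=O)N1Cc1ccccc1` is the one that stands apart; in this assay compound 1 gives 25000 nM, and the step of a 4.3-fold higher number from compound 1 to compound 2 (0.64 log units; beyond the scatter) is modest but beyond the scatter.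

Compound 4 `O=C1c2ccccc2N(Cc2ccccc2Cl)S(=O)(=O)N1Cc1ccccc1` differs from compound 2 in a single spot: chloro in place of hydrogen on an aromatic carbon. Neither measured step adds a small substituent to an aromatic ring; both exchange the whole group carried by one of the two ring nitrogens of the shared core, and only a 4.3-fold higher number from compound 1 to compound 2 (0.64 log units; beyond the scatter) concerns the group on the same nitrogen where the chloro now enters. The data therefore give no direct guide for this change, and the expectation is a step that stays within the scatter, a 1.3-fold lower number from compound 2 to compound 4 (0.10 log units; within the scatter). Compound 4 is accordingly expected to give about 85000 nM in this assay, with a likely range from 30000 nM to 220000 nM.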

Compound 4, half-maximal cytotoxic concentration: 27900 nM
Estimate against measurement, compound 4: 3.0-fold (0.48 log units) above, and the stated range ends above it.
By their numbers in this assay, from the lowest: compounds 1 and 4 (each within the scatter of the next); then compounds 3 and 2 (each within the scatter of the next).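

In this assay, a single chloro on an aromatic carbon, ortho to a large group, gives a 3.9-fold lower number from compound 2 to compound 4 (0.59 log units; beyond the scatter), so turning benzyl into 2-chlorobenzyl is enough to make the number fall beyond the scatter. The earlier steps shown here exchanged a whole group on a ring nitrogen, whereas this one shows that the number also responds to one added atom on the aromatic ring of that benzyl group. Compound 4 also cannot be separated from compound 1, as a 1.1-fold higher number from compound 1 to compound 4 (0.05 log units; within the scatter) shows. No measurement available here bears on this result.

Only the 2-chlorobenzyl group is shown, so it remains open whether the step belongs to chloro as such or to its place on the ring, and a fluoro, a methoxy or a nitrile on the same carbon could tell these apart, as could a chloro on another carbon of that ring. From the compounds shown here alone, it also remains open whether a chloro on the other benzyl group of the shared core, the one on the amide-type nitrogen, would move the number in the same way.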